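Pyridin-4-yl in Place of 4-Methoxyphenyl on the Amide

The source may hold more compounds than are shown below. What is called first, only, known or untested is meant among the compounds shown, and "the series" means these compounds.

Compound 1 `O=C(NC1CCN(Cc2ccccc2)CC1)c1c(O)c2cccnc2n(-c2ccccc2)c1=O` — 1.7%
Compound 2 `O=C(Nc1ccccc1)c1c(O)c2cccnc2n(-c2ccccc2)c1=O` — 4.6%
Compound 3 `COc1ccc(NC(=O)c2c(O)c3cccnc3n(-c3ccccc3)c2=O)cc1` — 0.3%

All three compounds share one core and differ only in the group carried on the amide-type nitrogen. In a functional assay on the whole organism for inhibition, with Rattus norvegicus as the target, read by paw edema, at a dose of 100 mg/kg by the oral route (a higher number here means more inhibition at the dose given (going by the name of the read-out), a lower number less inhibition), compound 1 gives 1.7%, compound 2 gives 4.6% and compound 3 gives 0.3%. Going by the values given here, on these numbers compound 3 has the lowest of the three, but the gap to compound 1 is within the scatter, and the one measured step, a number 4.3 percentage points lower from compound 2 to compound 3 (within the scatter), is within the scatter as well, so the three cannot be told apart; all sit close to no inhibition.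

Compound 4 `O=C(Nc1ccncc1)c1c(O)c2cccnc2n(-c2ccccc2)c1=O` differs from compound 3 by pyridin-4-yl in place of 4-methoxyphenyl on an amide-type nitrogen. Among the compounds with values here, the only step that bears on this change is the one from compound 2 to compound 3, which also swapped the group on the amide-type nitrogen and moved the number by an amount within the scatter. Nothing here suggests that a further swap at the same place would act differently, so the step of a number 2.7 percentage points higher from compound 3 to compound 4 (within the scatter) is expected to stay within the scatter. Compound 4 is therefore estimated at 3%, with a range from -6% to 14%.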

Compound 4, a percentage reported as inhibition, in the whole organism at one dose (the size of the read-out at that dose, not a potency): 34.9%
For compound 4 the middle estimate is 31.9 percentage points below the measured one; the whole stated range lies below it.
By their numbers in this assay, from the lowest: compounds 3, 1 and 2 (each within the scatter of the next); then compound 4.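

In this assay the group on the amide-type nitrogen turns out to matter, since this place had shown no step beyond the scatter until pyridin-4-yl gave a number 34.6 percentage points higher from compound 3 to compound 4 (beyond the scatter) and also a number 30.3 percentage points higher from compound 2 to compound 4 (beyond the scatter) in the second comparison. The second step is the plainer of the two: phenyl and pyridin-4-yl have the same ring size, and the entering ring has one hetero atom where the leaving ring has carbon only, so a single ring-atom change goes with the large rise, at least for this pair. Nothing available on these compounds explains why the number rises.

The compounds shown leave open whether the ring nitrogen must sit where it does in pyridin-4-yl, which pyridin-3-yl or pyridin-2-yl on the same amide-type nitrogen would test, and whether pyridin-4-ylmethyl, with a single carbon inserted, would hold the gain. They also leave open how the inhibition changes with dose, as every number here comes from one oral dose and is not a potency.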